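The source may hold more compounds than are shown below. What is called first, only, known or untested is meant among the compounds shown, and "the series" means these compounds.

Compound 1 `c1ccc(-c2ccc(Cn3cncc3CNc3cccc(-c4ccccc4)c3)cc2)cc1`: 10000 nM
Compound 2 `c1ccc(-c2ccc(Cn3cncc3CNc3ccc(-c4nc5ccccc5o4)c(-c4ccccc4)c3)cc2)cc1`: > 10000 nM
Compound 3 `CCC(=O)c1ccc(NCc2cncn2Cc2ccc(-c3ccccc3)cc2)cc1-c1ccccc1`: > 10000 nM

In a toxicity assay on NIH3T3 cells (Mus musculus) for cytotoxicity, read by resazurin assay (a lower number here means that less compound is needed, a higher number that more compound is needed for the effect), compound 1 gives 10000 nM. For compound 2 the assay reports only a limit, > 10000 nM. For compound 3 too the assay reports only a limit, > 10000 nM, so compound 3 stands at the limit of > 10000 nM in this assay, at which 2 of the 3 values shown sit, together with one other value. The steps of a number no lower from compound 1 to compound 2 (the limit leaves the size open) and a number no lower from compound 1 to compound 3 (the limit leaves the size open) are limits whose size cannot be read, and the step that the two limits leave unreadable from compound 2 to compound 3 is unreadable as well. Compound 4 `CCOC(=O)c1ccc(NCc2cncn2Cc2ccc(-c3ccccc3)cc2)cc1-c1ccccc1` differs from compound 3 by ethoxy in place of ethyl on a carbonyl carbon. Going by the values given here, no measured step shows this change, and no step here has a readable size, so no shift beyond the scatter is expected. Compound 4 is therefore estimated at 10000 nM, between 5000 nM and 30000 nM. The expected step is a number no higher from compound 3 to compound 4 (the limit leaves the size open).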

Compound 4, half-maximal effective concentration: > 10000 nM
Compound 4 was reported as a limit (the forecaster's own chance of this, stated with the estimate: 60%); the middle value sits exactly at the limit.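

Ethoxycarbonyl now joins propanoyl and 1,3-benzoxazol-2-yl on this aromatic carbon, and for all three groups this assay gives only a limit rather than a number. Ethoxycarbonyl in place of hydrogen on this aromatic carbon gives a number no lower from compound 1 to compound 4 (the limit leaves the size open). The steps linking compound 4 to compound 2 and compound 3 therefore cannot be read, so swapping ethyl for ethoxy on the carbonyl carbon has no measurable size here. The values shown now gather at one point: the limit of > 10000 nM in this assay, at which 3 of the 4 values shown sit.

From the compounds shown here alone, how far these compounds lie past that limit remains open. So does whether an amine or a carboxylic acid on this aromatic carbon would give a readable number.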